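This account rests on a few compounds, and the source may have more. Where it says the series, first, only, none or still open, it means among the compounds named here.

Compound 1 `C[C@@H](CCCN1CCCCC1)Nc1ccnc2cc(Cl)ccc12` — 150000 nM
Compound 2 `C[C@@H](CCCN(C)C)Nc1ccnc2cc(Cl)ccc12` — 150000 nM
Compound 3 `C[C@H](CCCN(C)C)Nc1ccnc2cc(Cl)ccc12` — 190000 nM

All three compounds share one core and were tested in an assay for binding affinity, read by spectrophotometry; a higher number here means a weaker inhibitor, a lower number a stronger inhibitor. Compound 2 stands level with compound 1 at the digits shown, the two of them together at the low end of the three numbers; compound 3 is the furthest from compound 2, and even that step, a 1.3-fold higher number from compound 2 to compound 3 (0.10 log units; within the scatter), stays within the scatter, so the three numbers cannot be told apart.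

Compound 4 `CCN(C)CCC[C@H](C)Nc1ccnc2cc(Cl)ccc12` has not yet been measured. It differs from compound 2 in one place: methyl in place of hydrogen on a saturated chain carbon bound to an amine nitrogen. Going by the values given here, two measured steps bear on this. The closest is no change at the digits printed from compound 1 to compound 2 (within the scatter), which rebuilt the groups on the same amine nitrogen far more drastically than a single added carbon and left the number unchanged. The other, a 1.3-fold higher number from compound 2 to compound 3 (0.10 log units; within the scatter), also stayed within the scatter, and it concerns only configuration (the fact that compounds 2 and 3 differ only in the configuration as drawn), so it says little about adding a carbon.

The expectation for compound 4 is therefore a step of no change at the digits printed from compound 2 to compound 4 (within the scatter), no larger than the scatter and in no particular direction. Compound 4 is estimated at 150000 nM, with a range from 75000 nM to 300000 nM.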

Compound 4, half-maximal inhibitory concentration: 150000 nM
Estimate against measurement, compound 4: no gap at the digits printed, within the range that was stated.
By their numbers in this assay, from the lowest: compounds 1, 2, 4 and 3 (each within the scatter of the next).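

In this assay, the smallest change yet at this position, methyl in place of hydrogen on a saturated chain carbon bound to an amine nitrogen, gives no change at the digits printed from compound 2 to compound 4 (within the scatter) and so turns dimethylamino into ethyl(methyl)amino. The earlier pair had tested only the larger exchange of piperidin-1-yl for dimethylamino, whereas ethyl(methyl)amino can now be set against the ring group directly, which gives no change at the digits printed from compound 1 to compound 4 (within the scatter) and adds a second comparison with the same outcome. Within compounds 1, 2 and 4, then, this assay does not separate a ring on the amine nitrogen, two methyl groups or a methyl with an ethyl, and no compound among them goes against that reading.

Nothing available accounts for this flat result, and the configuration of compounds 2 and 3 does not bear on the added methyl. As far as these compounds go, it remains open whether a group of another kind at the end of the chain, such as a carboxylic acid or a hydroxyethyl on the nitrogen, or a longer chain leading to the amine, would move the number beyond the scatter.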